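Swapping the phenyl group on compound 3

This account rests on a few compounds, and the source may have more. Where it says the series, first, only, none or still open, it means among the compounds named here.

Within the data shown here, in a functional assay on HCT-15 cells (Homo sapiens) for antiproliferative activity, read by MTT assay, with a stated time of 72 h (on this read-out lower numbers stand for stronger inhibition and higher numbers for weaker inhibition), compound 3 (`COc1cc(-c2nccn2-c2cccc(C)c2)cc(OC)c1OC`) gives 1600 nM as the only actual number in the set. Compound 1 (`COc1cc(-c2nccn2C(C)C)cc(OC)c1OC`) reaches only a limit (> 100000 nM). Compound 2 (`COc1cc(-c2nccn2CC(C)C)cc(OC)c1OC`) likewise reaches only a limit (> 100000 nM). Compound 4 (`COc1cc(-c2nccn2-c2ccc(F)cc2)cc(OC)c1OC`) carries 4-fluorophenyl in place of 3-methylphenyl on an aromatic nitrogen The measured steps bearing on this are an at least 62-fold lower number from compound 1 to compound 3 (1.79 log units; beyond the scatter) and an at least 62-fold lower number from compound 2 to compound 3 (1.79 log units; beyond the scatter) with 3-methylphenyl replacing isopropyl and isobutyl. Both are large, yet neither compares one substituted phenyl with another, so neither points to a direction here. The expected result in this assay is a 1.3-fold higher number from compound 3 to compound 4 (0.10 log units; within the scatter) and so no step beyond the scatter. Compound 4 is estimated at 2000 nM (expected range 500 nM to 10000 nM).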

Compound 4, half-maximal inhibitory concentration: 68600 nM
The estimate for compound 4 lay 34-fold (1.54 log units) below the measured number; measured number above the stated range.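

On the aromatic nitrogen, a phenyl ring alone does not secure the activity of compound 3: in this assay 4-fluorophenyl in place of 3-methylphenyl gives a 43-fold higher number from compound 3 to compound 4 (1.63 log units; beyond the scatter) and so separates two substituted phenyls. Against isobutyl and isopropyl, the series shows only an at least 1.4-fold lower number from compound 2 to compound 4 (0.16 log units; that floor lies within the scatter) and an at least 1.4-fold lower number from compound 1 to compound 4 (0.16 log units; that floor lies within the scatter) as the remaining comparisons. Both are floors set by an assay limit: the limit of > 100000 nM in this assay, at which 2 of the 4 values shown sit.

As far as these compounds go, it remains open whether 3-fluorophenyl or 4-methylphenyl would track compound 3 or compound 4. The identity of the substituent and its place on the phenyl ring therefore remain unseparated.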